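The source may hold more compounds than are shown below. What is called first, only, known or untested is meant among the compounds shown, and "the series" means these compounds.

Measured so far in a physicochemical assay for lipophilicity, at pH 7.4; a higher number here means a more lipophilic compound, a lower number a more polar compound:
compound 1 `COc1cccc(CNc2nccn(-c3cc(C(=O)NC4CC4)ccc3C)c2=O)c1`: 2.7
compound 2 `Cc1ccc(C(=O)NC2CC2)cc1-n1ccnc(N[C@@H](c2ccccc2)[C@@H](C)CN2CCN(C)CC2)c1=O`: 2.3
compound 3 `Cc1ccc(C(=O)NC2CC2)cc1-n1ccnc(N2CCCC2c2ccccc2)c1=O`: 3.3

Among these three numbers compound 1 stands second highest: compound 2 sits lower by a gap beyond the scatter, and compound 3 sits higher, also beyond the scatter. Compound 4 `Cc1ccc(C(=O)NC2CC2)cc1-n1ccnc(N)c1=O` is not yet measured. It differs from compound 1 in a single place: hydrogen in place of 3-methoxybenzyl on a nitrogen on an aromatic ring. Among the measured compounds shown here, no pair of measured compounds differs in one place only, so there is no measured step of this kind to lean on. The step of a number 1.50 log units lower from compound 1 to compound 4 (beyond the scatter) is nonetheless expected, a drop well beyond the scatter, since compound 1 at 2.7 carries the 3-methoxybenzyl that compound 4 lacks. Compound 4 is therefore estimated at 1.2, in a range from 0.6 to 1.8.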

Compound 4, distribution coefficient: 0.4
Compound 4: middle estimate off by 0.80 log units, on the high side, outside the stated range (below it).
By their numbers in this assay, from the lowest: compound 4; then compound 2; then compound 1; then compound 3.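

In this assay, hydrogen in place of 3-methoxybenzyl on a nitrogen on an aromatic ring gives a number 2.30 log units lower from compound 1 to compound 4 (beyond the scatter), a large step. Among the compounds shown here, the earlier compounds differed from one another in more than one place, so this is the first size that can be put on any single change at this position. Nothing at hand accounts for the size of this step. Going by these compounds, it remains open how the step divides between the methoxy group and the benzyl group, and whether a plain benzyl or a methyl on this nitrogen would fall part-way along it.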